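A few compounds are considered here, and "the series" means these few. Any claim that something is new, unique, unknown or untested is made for them only; others in the source may bear on it.

Compound 1 `Cc1ccc2nc(C(=O)Nc3c(F)cc(-c4cccc(F)c4)cc3F)c(C)c(O)c2c1` gives 25.5% in a functional assay on Hep 3B2 cells (Homo sapiens) for antiproliferative activity, read by MTT assay, with a stated time of 24 h, tested at 11.11 ug/mL; on this read-out lower numbers stand for a weaker effect and higher numbers for a stronger effect at the one concentration tested. Compound 2 `COc1ccc2nc(C(=O)Nc3ccc(-c4ccccc4)cc3)c(C)c(O)c2c1` gives 36.3% in this assay. Compound 3 `Cc1ccc2nc(C(=O)Nc3c(F)cc(-c4cccc(F)c4)cc3F)c(C)c(C(=O)O)c2c1` gives 35.6% in this assay.

Compound 1 and compound 3 share a core and differ in one place: carboxy in place of hydroxy on an aromatic carbon. That change made a number 10.1 percentage points higher from compound 1 to compound 3 (beyond the scatter). Compound 2 lies within the scatter of compound 3 in this assay, so no order between them can be read; the difference between the core of compound 2 and that of compound 1 is not broken down here.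

Compound 4 `COc1ccc2nc(C(=O)Nc3ccc(-c4ccccc4)cc3)c(C)c(C(=O)O)c2c1` has not been measured. It differs from compound 2 in one place: carboxy in place of hydroxy on an aromatic carbon. The place of this change is described in the same words as for the step from compound 1 to compound 3, so it is the same change, made on a different core. Because the earlier step gave a number 10.1 percentage points higher from compound 1 to compound 3 (beyond the scatter), the expected step from compound 2 to compound 4 is a number 7.7 percentage points higher from compound 2 to compound 4 (within the scatter), with some allowance for the core differing. Compound 4 is estimated at 44%, expected between 30% and 58%.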

Compound 4, a percentage reported as inhibition, at one concentration (the size of the read-out at that concentration, not a potency): 28.3%
Compound 4: middle estimate off by 15.7 percentage points, on the high side; the whole stated range lies above it.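

In this assay, carboxy in place of hydroxy on an aromatic carbon gave a number 8 percentage points lower from compound 2 to compound 4 (within the scatter), so on the core of compound 2 the change leaves no difference that can be read. Set beside the earlier step, the change did not keep its size from one core to the other: the same change on two cores in this assay, a number 10.1 percentage points higher (beyond the scatter) from compound 1 to compound 3 and a number 8 percentage points lower (within the scatter) from compound 2 to compound 4, 18.1 percentage points apart, beyond the scatter of two such steps. This shows that in this series the step seen on one core cannot be carried to another as a fixed amount, but two pairs do not show which feature of the cores accounts for the gap, or how the change would behave on a further core.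

The compounds shown leave open which of the differences between the two cores matters, as no compound separates the fluoro groups from the swap of methyl for methoxy. They also leave open how an amine or a primary amide would compare with hydroxy and carboxy in the same place.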